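Shortening the cyclohexyl side chain of compound 2

This account rests on a few compounds, and the source may have more. Where it says the series, first, only, none or still open, it means among the compounds named here.

Compound 1 `CC[C@H](C)[C@@H](CN(C(=O)[C@@H]1C[C@H]1c1ccccc1)c1ccc(-c2ccccc2)cc1)NC(C)=O` gives 5.8 nM in a functional assay for agonist activity at G protein-coupled receptor 88 (Homo sapiens), read by HTRF and cAMP accumulation; a higher number here means that more compound is needed for the effect, a lower number that less compound is needed. Compound 2 `N[C@@H](CC1CCCCC1)CN(C(=O)[C@@H]1C[C@H]1c1ccccc1)c1ccc(-c2ccccc2)cc1` gives 1.7 nM in this assay and stands lowest of the two numbers; the step of a 3.4-fold lower number from compound 1 to compound 2 (0.53 log units; beyond the scatter) separates the pair. Compound 3 `N[C@H](CN(C(=O)[C@@H]1C[C@H]1c1ccccc1)c1ccc(-c2ccccc2)cc1)C1CCCCC1` carries cyclohexyl in place of cyclohexylmethyl on a saturated chain carbon bound to an amine nitrogen and a saturated chain carbon. For the measured compounds named here, no measured step addresses this change on its own: the step of a 3.4-fold lower number from compound 1 to compound 2 (0.53 log units; beyond the scatter) alters the amine and the side chain together and shows only that a cyclohexyl-bearing chain is tolerated. The change is therefore expected to give a small step, a 2.1-fold higher number from compound 2 to compound 3 (0.31 log units; beyond the scatter), if anything toward a higher number. Compound 3 is estimated at 3.5 nM, within 1 nM to 12 nM.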

Compound 3, half-maximal effective concentration: 0.66 nM
The estimate for compound 3 lay 5.3-fold (0.72 log units) above the measured number; measured number below the stated range.
By their numbers in this assay, from the lowest: compound 3; then compound 2; then compound 1.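

Replacing cyclohexylmethyl with cyclohexyl on the saturated chain carbon bound to an amine nitrogen and a saturated chain carbon gives a 2.6-fold lower number from compound 2 to compound 3 (0.41 log units; beyond the scatter) in this assay, so the shorter link to the ring is favoured in this pair. Amino(cyclohexyl)methyl in place of 1-acetamido-2-methylbutyl gives an 8.8-fold lower number from compound 1 to compound 3 (0.94 log units; beyond the scatter), a larger step, but it alters the nitrogen substituent and the side chain together. No available evidence explains either step.

Open, as far as these compounds go, is whether cyclopentyl, phenyl or isopropyl at this place would match cyclohexyl. Also open, from the compounds shown here alone, is how an acetamide on the cyclohexyl compound would compare with the free amine.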